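A few compounds are considered here, and "the series" means these few. Any claim that something is new, unique, unknown or untested is made for them only; others in the source may bear on it.

Compound 3 `Cc1ccc(C(=O)Nc2sc3c(c2C(N)=O)CCN(C(=S)Nc2ccccc2Cl)C3)cc1` gives the lowest of the three numbers in a functional assay on HL-60 cells (Homo sapiens) for antiproliferative activity, with a stated time of 24 h (a higher number here means a weaker inhibitor, a lower number a stronger inhibitor), with 8430 nM. Compound 1 `Cc1ccccc1C(=O)Nc1sc2c(c1C(N)=O)CCN(C(=S)Nc1ccccc1Cl)C2` gives 20900 nM, and compound 2 `COc1ccccc1C(=O)Nc1sc2c(c1C(N)=O)CCN(C(=S)Nc1ccccc1Cl)C2` gives 20800 nM. Compound 4 `NC(=O)c1c(NC(=O)c2cccc([N+](=O)[O-])c2)sc2c1CCN(C(=S)Nc1ccccc1Cl)C2` differs from compound 3 by 3-nitrophenyl in place of 4-methylphenyl on a carbonyl carbon. Among the measured compounds shown here, three measured steps bear on changes at this same ring: a 2.5-fold lower number from compound 1 to compound 3 (0.39 log units; beyond the scatter), a 2.5-fold lower number from compound 2 to compound 3 (0.39 log units; beyond the scatter) and a 1.0-fold lower number from compound 1 to compound 2 (0.00 log units; within the scatter). For the measured compounds named here, each of them stayed modest, and the only group that gave a lower number was the 4-methylphenyl that now leaves. A nitro group has not been tested here. Compound 4 is therefore expected to show an estimated step of a 1.8-fold higher number from compound 3 to compound 4 (0.25 log units; within the scatter). Compound 4 is estimated at 15000 nM, within a range of 5000 nM to 40000 nM.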

Compound 4, half-maximal inhibitory concentration: 7040 nM
Compound 4: the middle estimate sits 2.1-fold (0.33 log units) above what was measured, within the range that was stated.
By their numbers in this assay, from the lowest: compounds 4 and 3 (each within the scatter of the next); then compounds 2 and 1 (each within the scatter of the next).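

In this assay the swap to 3-nitrophenyl gives a 1.2-fold lower number from compound 3 to compound 4 (0.08 log units; within the scatter) and so costs nothing measurable, showing that this position tolerates a ring carrying a nitro group as well as the 4-methylphenyl. Set against the other two rings, the 3-nitrophenyl gives a 3.0-fold lower number from compound 2 to compound 4 (0.47 log units; beyond the scatter) and a 3.0-fold lower number from compound 1 to compound 4 (0.47 log units; beyond the scatter) and both steps are modest, so the 4-methylphenyl is no longer the only group here to give a lower number than they do. Nothing given here explains these steps. Still open, from the compounds shown here alone, is whether an amine or a carboxylic acid on this ring, or a longer chain on the carbonyl carbon in place of the ring, would shift the number further.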